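Ethoxycarbonyl in place of 2-(dimethylamino)ethyl on the shared core

The source may hold more compounds than are shown below. What is called first, only, known or untested is meant among the compounds shown, and "the series" means these compounds.

Among the compounds with values here, in a functional assay with Mus musculus as the target (on this read-out higher numbers stand for an effect only at larger amounts of compound and lower numbers for an effect already at smaller amounts), compound 3 `CN(C)CCCn1c(=O)n(C2OC(CO)[C@@H](O)[C@H]2O)c2nc(N)nc(O)c21` gives 820 uM, the highest number of the three measured so far. Compound 1 `Nc1nc(O)c2c(n1)n(C1OC(CO)[C@@H](O)[C@H]1O)c(=O)n2C/C=C/c1ccccc1` gives 4 uM, and compound 2 `COc1ccc(Cn2c(=O)n(C3OC(CO)[C@@H](O)[C@H]3O)c3nc(N)nc(O)c32)cc1` gives 2 uM. These two lie within the scatter of each other, as a 2.0-fold lower number from compound 1 to compound 2 (0.30 log units; within the scatter) shows.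

Compound 4 `CCOC(=O)Cn1c(=O)n(C2OC(CO)[C@@H](O)[C@H]2O)c2nc(N)nc(O)c21` differs from compound 3 on a saturated chain carbon bound to an aromatic nitrogen, with ethoxycarbonyl in place of 2-(dimethylamino)ethyl (ethoxycarbonyl in place of 2-(dimethylamino)ethyl on a saturated chain carbon bound to an aromatic nitrogen). Two measured steps at that same place bear on this change, and both are large: a 210-fold higher number from compound 1 to compound 3 (2.31 log units; beyond the scatter) and a 410-fold higher number from compound 2 to compound 3 (2.61 log units; beyond the scatter). Both replace a group named with a phenyl ring, whereas ethoxycarbonyl has no ring, so neither step tests it directly. Only part of that large gap is therefore expected to close, and a moderate step toward a lower number is expected, an 8.2-fold lower number from compound 3 to compound 4 (0.91 log units; beyond the scatter). The estimate for compound 4 is 100 uM, with an expected range from 15 uM to 700 uM.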

Compound 4, concentration for half-maximal effect: 630 uM
For compound 4 the middle estimate is 6.3-fold (0.80 log units) below the measured one; low and high end bracket the measured number.
By their numbers in this assay, from the lowest: compounds 2 and 1 (each within the scatter of the next); then compounds 4 and 3 (each within the scatter of the next).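

In this assay, the step from the amine-bearing group to the ester-bearing one is small (a 1.3-fold lower number from compound 3 to compound 4 (0.11 log units; within the scatter)), so 2-(dimethylamino)ethyl and ethoxycarbonyl, both ringless and of equal heavy-atom count, cannot be told apart at this position. The large distance from the ring-bearing compounds therefore holds for a second ringless group (a 320-fold higher number from compound 2 to compound 4 (2.50 log units; beyond the scatter); a 160-fold higher number from compound 1 to compound 4 (2.20 log units; beyond the scatter)), and among these four compounds none goes against that division. Nothing shown gives a reason for this division.

As far as these compounds go, it remains open whether a plain saturated alkyl chain or a cyclohexyl group on the same saturated chain carbon would fall with compound 3 and compound 4 or with compound 1 and compound 2. The compounds shown also leave open how a carboxylic acid in place of ethoxycarbonyl would read.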